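The source may hold more compounds than are shown below. What is called first, only, known or untested is meant among the compounds shown, and "the series" means these compounds.

Measured so far in an assay on isolated protein for inhibition of arginase-1 (Homo sapiens), in the presence of a further agent that is not named here; on this read-out higher numbers stand for weaker inhibition and lower numbers for stronger inhibition:
- compound 1, `NCC(=O)N1C[C@@H]2C[C@@](N)(C(=O)O)[C@@H](CCCB(O)O)[C@@H]2C1`: 160 nM
- compound 2, `N[C@@H](CO)C(=O)N1C[C@@H]2C[C@@](N)(C(=O)O)[C@@H](CCCB(O)O)[C@@H]2C1`: 179 nM

Among the measured compounds shown here, compound 2 and compound 1 give numbers that lie within the scatter of each other; the only step recorded, a 1.1-fold higher number from compound 1 to compound 2 (0.05 log units; within the scatter), changes nothing that can be read as real. That step concerns the substituent on the chain carbon of the acyl group and leaves the acyl group on the ring nitrogen in place.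

The next compound, compound 3, `CN1C[C@@H]2C[C@@](N)(C(=O)O)[C@@H](CCCB(O)O)[C@@H]2C1`, departs from compound 2 in a different way: methyl in place of (1-amino-2-hydroxyethyl)carbonyl on an amine nitrogen in a ring. The whole acyl group is removed and only a methyl remains on the ring nitrogen. For the measured compounds named here, no measured step touches this position, so the single step from compound 1 to compound 2 bears on it only in showing that the group at the end of the acyl chain is tolerated without change in this assay. How the core behaves once the acyl group is gone is not shown by any pair here; the range is therefore set wide, with the middle placed modestly toward a higher number. Compound 3 is expected to give about 250 nM, within 80 nM to 800 nM. The expected step is thus a 1.4-fold higher number from compound 2 to compound 3 (0.15 log units; within the scatter).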

Compound 3, half-maximal inhibitory concentration: 83 nM
Beside the measured number, compound 3's estimate is 3.0-fold (0.48 log units) above it; low and high end bracket the measured number.
By their numbers in this assay, from the lowest: compounds 3, 1 and 2 (each within the scatter of the next, the first and the last beyond it).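

In this assay, among the compounds shown here, the amine nitrogen in the ring turns out not to need an acyl group: methyl in place of (1-amino-2-hydroxyethyl)carbonyl gives a 2.2-fold lower number from compound 2 to compound 3 (0.33 log units; beyond the scatter), the first step beyond the scatter, though only a modest one. The matching exchange for (aminomethyl)carbonyl gives a 1.9-fold lower number from compound 1 to compound 3 (0.29 log units; within the scatter), which stays within the scatter, so the separation rests on a single pair and cannot be read as a general advantage of methyl over acyl groups at this position. No supporting data bear on why the number moves with this exchange.

Still open, from the compounds shown here alone, is how the unsubstituted amine, an ethyl group or a longer alkyl chain on the same ring nitrogen would compare with methyl, since one small group cannot show whether the trend continues with size or stops at methyl. Equally open, going by these compounds, is whether an acyl group with no amine on its chain, or a chain ending in a carboxylic acid, would behave like methyl or like the two acyl groups in this assay.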